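Longer Hydroxylated Chain Replaces Oxolane on the Carbonyl

The source may hold more compounds than are shown below. What is called first, only, known or untested is meant among the compounds shown, and "the series" means these compounds.

Measured compounds, all in a functional assay on DU-145 cells (Homo sapiens) for cytotoxicity, read by MTT assay; on this read-out lower numbers stand for stronger inhibition and higher numbers for weaker inhibition:
- compound 1 `CC(C)=CC[C@@H](OC(=O)CCO)C1=CC(=O)c2c(O)ccc(O)c2C1=O` gives 55300 nM
- compound 2 `CC(C)=CC[C@@H](OC[C@H](C)O)C1=CC(=O)c2c(O)ccc(O)c2C1=O` gives 24500 nM
- compound 3 `CC(C)=CC[C@@H](OC(=O)C1CCOC1)C1=CC(=O)c2c(O)ccc(O)c2C1=O` gives 47500 nM

Within this small set, compound 3 holds the second highest of the three numbers in this assay. Its nearest neighbour is compound 1, with a 1.2-fold lower number from compound 1 to compound 3 (0.07 log units; within the scatter), and even the gap to compound 2, a 1.9-fold higher number from compound 2 to compound 3 (0.29 log units; within the scatter), stays within the usual scatter, so the three compounds cannot be ranked with confidence.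

Compound 4 `CCCCC(C)(O)CC(=O)O[C@H](CC=C(C)C)C1=CC(=O)c2c(O)ccc(O)c2C1=O` differs from compound 3 at the carbonyl carbon: 2-hydroxy-2-methylhexyl in place of oxolan-3-yl on a carbonyl carbon. Among the compounds with values here, the measured step that bears most directly on this exchange is the one between compound 1 and compound 3, which likewise swapped the group on the carbonyl carbon and gave a 1.2-fold lower number from compound 1 to compound 3 (0.07 log units; within the scatter). The other two steps, a 2.3-fold lower number from compound 1 to compound 2 (0.35 log units; beyond the scatter) and a 1.9-fold higher number from compound 2 to compound 3 (0.29 log units; within the scatter), changed the whole group on the oxygen on a saturated carbon and reached at most a modest shift. Within the data shown here, since the only change of the same kind stayed within the scatter, no step beyond the scatter is expected here. The expected step for compound 4 in this assay is therefore a 1.1-fold lower number from compound 3 to compound 4 (0.02 log units; within the scatter). Compound 4 is thus estimated at 45000 nM, with a range from 20000 nM to 100000 nM.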

Compound 4, half-maximal inhibitory concentration: 76500 nM
Estimate against measurement, compound 4: 1.7-fold (0.23 log units) below; the range from low to high includes it.
By their numbers in this assay, from the lowest: compounds 2, 3, 1 and 4 (each within the scatter of the next, the first and the last beyond it).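

Exchanging the ring of oxolan-3-yl on the carbonyl carbon for the open chain of 2-hydroxy-2-methylhexyl, with 8 heavy atoms in place of 5 and a hydrogen-bond donor the ring lacks, gives a 1.6-fold higher number from compound 3 to compound 4 (0.21 log units; within the scatter) in this assay and so does not move the number beyond the scatter. Within the data shown here, the same holds for the exchange against the short hydroxylated chain, where 1-hydroxy-1-methylpentyl in place of hydroxymethyl gives a 1.4-fold higher number from compound 1 to compound 4 (0.14 log units; within the scatter) and this position again shows no step beyond the scatter, now across a much wider range of groups than the earlier compounds covered. Among these compounds, the one new step beyond the scatter, and only a modest one, is a 3.1-fold higher number from compound 2 to compound 4 (0.49 log units; beyond the scatter) and replaces the whole group on the oxygen on a saturated carbon, so it does not isolate the carbonyl position. Nothing shown gives a reason for these numbers. As far as these compounds go, whether an amine or a carboxylic acid at the end of the chain on the carbonyl carbon would bring a step beyond the scatter stays open, as does whether any of these groups would behave the same way on cells other than those of this single assay.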